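The compounds below may be only part of what the source reports. "The series", "measured", "known", "first", "only" and "open" are said of these compounds alone.

Measured so far:
compound 1, `COc1cc2nc(NCc3ccccc3)nc(NC3CCCCCC3)c2cc1OC` — < 0%
compound 2, `COc1cc2nc(N3CCC(N4CCCC4)CC3)nc(N3CCCCC3)c2cc1OC` — 19%
compound 3, `COc1cc2nc(N3CCC(Cc4ccccc4)CC3)nc(NC3CCCCCC3)c2cc1OC` — < 0%

Among the compounds with values here, in an in vitro assay on B300-19 cells for displacement of a labelled ligand from C-C chemokine receptor type 4 (Homo sapiens), tested at 1 uM (on this read-out higher numbers stand for more inhibition at the one concentration tested (going by the name of the read-out) and lower numbers for less inhibition), compound 2 gives 19%, which is the only actual number in the set. For compound 1 the result in this assay is a limit of the assay, < 0%. For compound 3 the result is likewise a limit, < 0%. Two of the three results therefore sit at the limit of < 0% in this assay, at which 2 of the 3 values shown sit, and compound 2 stands alone above it with a higher number in this assay.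

Compound 4, `COc1cc2nc(N3CCC(N4CCCC4)CC3)nc(NCc3ccccc3)c2cc1OC`, is not yet measured. It differs from compound 2 in a single place: benzylamino in place of piperidin-1-yl on an aromatic carbon. The pyrrolidinylpiperidine of compound 2 is kept. Within the data shown here, no measured pair isolates this change, so its effect cannot be read off. Compound 1 also carries benzylamino, and in this assay compound 1 returns a limit, but it differs from compound 4 elsewhere as well, so only its value is known, not the step.

The expected step of a number 11 percentage points lower from compound 2 to compound 4 (beyond the scatter) is a small loss, not clearly beyond the scatter. Compound 4 is estimated at 8%, within -10% to 25%, with a fair chance that only a limit is reported.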

Compound 4, a percentage reported as inhibition, at one concentration (the size of the read-out at that concentration, not a potency): < 0%
Compound 4: only a limit was reported; the forecaster's own chance of this, stated with the estimate: 40%; middle value at least 8 percentage points from the limit.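

In this assay, benzylamino in place of piperidin-1-yl on the aromatic carbon next to the ring nitrogen gives a number at least 19 percentage points lower from compound 2 to compound 4 (beyond the scatter). On these data alone, compound 4 gives < 0%, which is a limit of the assay and not a number, so the true size of this step stays unknown. This is the first pair in the series that differs in one place, and it shows that keeping the pyrrolidinylpiperidine does not by itself hold the reading of this pair above the limit, with the result now sitting alongside most of the set: the limit of < 0% in this assay, at which 3 of the 4 values shown sit.

The compounds shown do not separate the part played by the aromatic ring of benzylamino from that of its amine hydrogen, and a morpholin-4-yl or an N-methylbenzylamino group at this position would speak to that. Within the data shown here, they also leave open whether any group here carries the reading of this assay beyond that of compound 2, 19%, since piperidin-1-yl is the only group at this position that gives a number.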